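This account rests on a few compounds, and the source may have more. Where it says the series, first, only, none or still open, it means among the compounds named here.

In a functional assay on MCF7 cells (Homo sapiens) for cytotoxicity, read by MTT assay, with a stated time of 72 h (on this read-out lower numbers stand for stronger inhibition and higher numbers for weaker inhibition), compound 1 (`CCN(CC)CCNC(=O)Nc1nc2ccc(-c3cnc(OC)c(NS(=O)(=O)c4ccc(F)cc4F)c3)cn2n1`) gives 740 nM and compound 2 (`CCN(CC)CCNC(=O)Nc1nc2ccc(-c3cnc(OC)c(NS(=O)(=O)c4ccc(Cl)cc4)c3)cn2n1`) gives 680 nM, so compound 2 stands level with compound 1 within the scatter. Compound 3 (`CCN(CC)CCNC(=O)Nc1nc2ccc(-c3cnc(OC)c(NS(=O)(=O)c4ccc(C)cc4)c3)cn2n1`) differs from compound 2 by methyl in place of chloro on an aromatic carbon. Among the measured compounds shown here, the only measured step bearing on this, a 1.1-fold lower number from compound 1 to compound 2 (0.04 log units; within the scatter), put 4-chlorophenyl in place of 2,4-difluorophenyl on a sulfonyl sulfur. For the measured compounds named here, with that as the only guide, no change beyond the scatter is expected in this assay. The expected step is a 1.0-fold higher number from compound 2 to compound 3 (0.01 log units; within the scatter). For compound 3 the estimated value is 700 nM, with a range from 350 nM to 1400 nM.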

Compound 3, half-maximal inhibitory concentration: 410 nM
Estimate against measurement, compound 3: 1.7-fold (0.23 log units) above, within the range that was stated.
By their numbers in this assay, from the lowest: compounds 3, 2 and 1 (each within the scatter of the next).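

At this carbon, para to a large group, this assay does not separate methyl from chloro: it shows a 1.7-fold lower number from compound 2 to compound 3 (0.22 log units; within the scatter). The 4-methylphenyl group also stays level with the 2,4-difluorophenyl group on the sulfonyl sulfur, with a 1.8-fold lower number from compound 1 to compound 3 (0.26 log units; within the scatter), so all three aryl groups shown read alike within the scatter. Nothing available gives a reason for these numbers. The compounds shown leave open whether an amine or a carboxylic acid on this carbon would give a step beyond the scatter, and whether a plain methyl on the sulfonyl sulfur, in place of the aryl group, would do so.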